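A few compounds are considered here, and "the series" means these few. Any claim that something is new, unique, unknown or untested is made for them only; others in the source may bear on it.

Working notes on the series. The shared core carries a five-membered aromatic ring on an aromatic carbon, as in compound 1 `c1c[nH]c(-c2ccccc2OCC2=NCCN2)c1` and compound 2 `c1ccc(-c2cc[nH]n2)c(OCC2=NCCN2)c1`. In a functional assay for activation of Alpha-1D adrenergic receptor (Homo sapiens), read by calcium flux (a higher number here means that more compound is needed for the effect, a lower number that less compound is needed), compound 1 gives 6.31 nM. For compound 2 the assay reports only a limit, namely < 100000 nM. Among the measured compounds shown here, the step that the limit leaves unreadable from compound 1 to compound 2 is accordingly of unreadable size; the only evidence on it is the limit of < 100000 nM in this assay, at which 1 of the 2 values shown sits. Compound 3 `c1ccc(-c2ncc[nH]2)c(OCC2=NCCN2)c1` is the next member, and the change from compound 2 is 1H-imidazol-2-yl in place of 1H-pyrazol-3-yl on an aromatic carbon. For the measured compounds named here, no measured step with a readable size bears on this change, since a step that the limit leaves unreadable from compound 1 to compound 2 cannot be read, so the expectation for compound 3 in this assay rests mainly on compound 1 and its value 6.31 nM. The estimate for compound 3 amounts to a step that the limit leaves unreadable from compound 2 to compound 3. Compound 3 is expected to give about 500 nM, with a range from 20 nM to 20000 nM.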

Compound 3, half-maximal effective concentration: < 100000 nM
Compound 3 gave a limit, no number; the forecaster's own chance of this, stated with the estimate: 25%; the middle value is on the limit's open side.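

Compound 3, like compound 2, gives only a limit in this assay, so no step among compound 1, compound 2 and compound 3 can be read: the limit of < 100000 nM in this assay, at which 2 of the 3 values shown sit.

Still open, from the compounds shown here alone, is how far compound 2 and compound 3 lie from compound 1, and whether 1H-pyrazol-3-yl and 1H-imidazol-2-yl differ at all in this assay.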